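The source may report more compounds than this note shows. Statements on the series, on what has been measured and on what is new or still open speak of the compounds shown alone.

Compound 1 (`Clc1ccccc1Cn1ccc2nc(-c3ccccc3)nc-2c1`) and compound 2 (`N#Cc1ccc(Cn2ccc3nc(-c4ccccc4)nc-3c2)cc1`) share a core and differ in the aromatic group on the saturated chain carbon bound to an aromatic nitrogen. In an ADME assay on MDBK cells (Bos taurus) for cytotoxicity (a higher number here means that more compound is tolerated, a lower number that less compound is tolerated), compound 1 gives > 100000 nM, which is a limit of the assay and not a number. In this assay, compound 2 gives > 100000 nM, which is also a limit. The evidence so far is therefore thin: the limit of > 100000 nM in this assay, at which 2 of the 2 values shown sit. Among the compounds with values here, the only measured step is a step that the two limits leave unreadable from compound 1 to compound 2, so it offers no size to carry forward.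

Compound 3 (`O=C(O)c1ccc(Cn2ccc3nc(-c4ccccc4)nc-3c2)cc1`) keeps everything in compound 2 except one group, with carboxy in place of cyano on an aromatic carbon. This exact change has not been measured elsewhere in the series. For compound 3, no step beyond the scatter is expected in either direction in this assay, because compound 2 sits at > 100000 nM. The expected change is a number no higher from compound 2 to compound 3 (the limit leaves the size open), and another limit is the likeliest report. Compound 3 is estimated at 100000 nM, with an expected range of 50000 nM to 200000 nM.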

Compound 3, half-maximal cytotoxic concentration: > 100000 nM
Compound 3 gave a limit, no number; the forecaster's own chance of this, stated with the estimate: 85%; the middle value sits exactly at the limit.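

In this assay compound 3 gives > 100000 nM, which is again a limit of the assay and not a number. The step between compound 2 and compound 3 cannot be read, as both results are limits. The compounds shown leave open at what concentration any of them harms these cells, and whether changing the group would shift it, with only this to go on: the limit of > 100000 nM in this assay, at which 3 of the 3 values shown sit.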